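The source may hold more compounds than are shown below. What is called first, only, known or untested is meant among the compounds shown, and "the series" means these compounds.

Compound 1, `Cc1ccc2c(Cc3nn4cc(-c5ccc(Cl)cc5)nc4s3)coc2c1`: 55.9%
Compound 2, `Cc1ccc2c(Cc3nn4cc(-c5ccc(Br)cc5)nc4s3)coc2c1`: 11.1%

For the measured compounds named here, in a functional assay on the whole organism (strain Wistar albino) for inhibition, with Rattus norvegicus as the target, read by paw edema, with a stated time of 4 h, at a dose of 100 mg/kg by the oral route (a higher number here means more inhibition at the dose given (going by the name of the read-out), a lower number less inhibition), compound 1 gives 55.9%, and compound 2 gives 11.1%, the lowest of the two numbers; the only measured step, a number 44.8 percentage points lower from compound 1 to compound 2 (beyond the scatter), lies beyond the scatter. Compound 3, `Cc1ccc2c(Cc3nn4cc(-c5ccc([N+](=O)[O-])cc5)nc4s3)coc2c1`, differs from compound 2 by nitro in place of bromo on an aromatic carbon. Going by the values given here, no measured step swaps a halogen for a nitro group on an aromatic carbon, so the direction is open; the one step of a number 44.8 percentage points lower from compound 1 to compound 2 (beyond the scatter) only shows that a change at this aromatic carbon can shift the read-out greatly. Compound 3 is therefore expected to give about 35%, within 10% to 60%. The expected step is a number 23.9 percentage points higher from compound 2 to compound 3 (beyond the scatter), a cautious rise.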

Compound 3, a percentage reported as inhibition, in the whole organism at one dose (the size of the read-out at that dose, not a potency): 45.7%
Beside the measured number, compound 3's estimate is 10.7 percentage points below it; the range from low to high includes it.
By their numbers in this assay, from the lowest: compound 2; then compound 3; then compound 1.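

In this assay, nitro in place of bromo gives a number 34.6 percentage points higher from compound 2 to compound 3 (beyond the scatter), so the low value of compound 2 does not extend to every group that can replace chloro at this aromatic carbon. Nitro in place of chloro gives a number 10.2 percentage points lower from compound 1 to compound 3 (beyond the scatter), a modest step that still leaves compound 1 the highest of the three. Nothing measured here says why the bromo compound stands apart. From the compounds shown here alone, whether an amine or a carboxylic acid at this carbon would sit nearer compound 1 or compound 2 remains open.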